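The source may report more compounds than this note shows. Statements on the series, on what has been measured and on what is new or still open speak of the compounds shown alone.

In a functional assay on MDA-MB-231 cells (Homo sapiens) for antiproliferative activity, read by MTT assay, with a stated time of 48 h (a lower number here means a stronger inhibitor, a higher number a weaker inhibitor), compound 3 `O=Cc1ccc(C2=C(c3ccccc3)C3(C=CC(=O)C=C3)OC2=O)s1` gives 19800 nM, the highest of the three numbers recorded. Compound 1 `O=C1C=CC2(C=C1)OC(=O)C(c1ccc([N+](=O)[O-])cc1)=C2c1ccccc1` gives 19000 nM in this assay, and compound 2 `N#Cc1ccc(C2=C(c3ccccc3)C3(C=CC(=O)C=C3)OC2=O)cc1` gives 8740 nM. The steps that reach compound 3 are a 1.0-fold higher number from compound 1 to compound 3 (0.02 log units; within the scatter) and a 2.3-fold higher number from compound 2 to compound 3 (0.36 log units; beyond the scatter), while the step of a 2.2-fold lower number from compound 1 to compound 2 (0.34 log units; beyond the scatter) sets the spread among the three. Compound 4 `O=C1C=CC2(C=C1)OC(=O)C=C2c1ccccc1` differs from compound 3 by hydrogen in place of 5-formylthiophen-2-yl on a double-bonded ring carbon. Among the compounds with values here, both measured steps onto compound 3 exchange one aromatic substituent at that position for another; no measured step removes the substituent altogether, so the present data give only an indirect guide. The widest step seen is modest, and a change that strips the substituent to a hydrogen is a larger departure than any of those exchanges. It is therefore expected that compound 4 gives a somewhat higher number in this assay, an estimated step of a 1.8-fold higher number from compound 3 to compound 4 (0.25 log units; within the scatter), with considerable uncertainty. The estimate for compound 4 is 35000 nM, expected to lie between 10000 nM and 120000 nM.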

Compound 4, half-maximal inhibitory concentration: 15900 nM
Compound 4: the middle estimate sits 2.2-fold (0.34 log units) above what was measured; measured number inside the range.
By their numbers in this assay, from the lowest: compounds 2, 4, 1 and 3 (each within the scatter of the next, the first and the last beyond it).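

In this assay, replacing the aromatic substituent on the double-bonded ring carbon with hydrogen gives a number within the scatter of all three substituted compounds (in turn a 1.2-fold lower number from compound 3 to compound 4 (0.10 log units; within the scatter); a 1.2-fold lower number from compound 1 to compound 4 (0.08 log units; within the scatter); a 1.8-fold higher number from compound 2 to compound 4 (0.26 log units; within the scatter)). The earlier compounds shown here only exchanged one aromatic group for another here, whereas compound 4 shows that no such group is needed for activity of this size, even though compound 2 and compound 3 stand beyond the scatter of each other. Nothing shown here offers an explanation for this result.

As far as these compounds go, it remains open whether another kind of group at this ring carbon, such as an amine, a carboxylic acid or a longer chain, would move the number beyond the scatter of compound 4. From the compounds shown here alone, the role of the phenyl group on the next ring atom also remains open.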